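The source may hold more compounds than are shown below. What is called first, only, known or untested is meant among the compounds shown, and "the series" means these compounds.

Of the compounds shown here, three have so far been read in an in vitro ADME assay on microsomes (Rattus norvegicus) for metabolic stability (on this read-out lower numbers stand for a shorter-lived compound and higher numbers for a longer-lived compound), and their numbers lie close together. Compound 1 `CCc1nc(-c2ccc(Cl)cc2Cl)c(CC)nc1NC(C1CC1)C1CC1` gives 0.0417 h, level with compound 3 `CCc1nc(-c2ccc(OC)nc2OC)c(CC)nc1NC(CC)CC` at 0.0417 h. Compound 2 `CCc1nc(-c2ccc(OC)cc2C(F)(F)F)c(CC)nc1NC(CC)CC` gives 0.0717 h, which is within the usual scatter of both, so the three cannot be ranked on these numbers.

Compound 4 `CCc1nc(-c2ccc(Cl)cc2Cl)c(CC)nc1SC(C)CC` has not yet been measured. It keeps the core of compound 1 and its 2,4-dichlorophenyl group, and it differs in one place: (sec-butyl)sulfanyl in place of (dicyclopropylmethyl)amino on an aromatic carbon. In words, (sec-butyl)sulfanyl stands in place of (dicyclopropylmethyl)amino on an aromatic carbon, next to the ring nitrogen and para to the 2,4-dichlorophenyl group.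

For the measured compounds named here, no measured pair differs at this place alone, so the data hold no direct step to lean on. Going by the values given here, the only guide is the narrow spread of the three measured compounds, which differ from one another in more than one place. What is expected in this assay is therefore no step beyond the scatter, and the estimated change, a 1.2-fold higher number from compound 1 to compound 4 (0.08 log units; within the scatter), is small. The estimate for compound 4 is 0.05 h, with an expected range from 0.025 h to 0.12 h.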

Compound 4, half-life: 0.0683 h
For compound 4 the middle estimate is 1.4-fold (0.14 log units) below the measured one; the measured number falls inside the stated range.
By their numbers in this assay, from the lowest: compounds 1, 3, 4 and 2 (each within the scatter of the next).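

In this assay, for the compounds shown here, the step (a 1.6-fold higher number from compound 1 to compound 4 (0.21 log units; within the scatter)) is the first that can be read at this place alone, with the core of compound 1 and its 2,4-dichlorophenyl group held constant. The change is not a small one on paper: (sec-butyl)sulfanyl brings sulfur to the aromatic carbon in place of nitrogen, gives up both three-membered rings and the hydrogen-bond donor, and has fewer heavy atoms, yet the read-out stays within the usual scatter. This single pair therefore shows that, on this dichlorophenyl compound, an open-chain sulfur-linked group and a ring-bearing amino group cannot be told apart in this read-out, and no available evidence explains that result.

From the compounds shown here alone, the step alters the linking atom and the carbon group together, so the share of each stays unknown; a sec-butylamino group or a dicyclopropylmethylsulfanyl group at this place would separate the two. Going by these compounds, it also remains open whether an ether oxygen, a carboxylic acid or a longer chain here would move the number beyond the scatter.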